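This account rests on a few compounds, and the source may have more. Where it says the series, first, only, none or still open, it means among the compounds named here.

Working notes on the series. Compound 1 `CCCCCCCCNC(=O)[C@@H](NC(=O)c1ccccc1)[C@@H](C)O` and compound 2 `CCCCCCCCCCCCCCCCCCNC(=O)[C@@H](NC(=O)c1ccccc1)[C@@H](C)O` differ only in the length of the chain on the amide nitrogen. In a functional assay on SiHa cells (Homo sapiens) for cytotoxicity, read by MTT assay, with a stated time of 48 h (on this read-out higher numbers stand for weaker inhibition and lower numbers for stronger inhibition), compound 1 gives 112000 nM, while compound 2 gives 38200 nM. That step is a 2.9-fold lower number from compound 1 to compound 2 (0.47 log units; beyond the scatter). For the measured compounds named here, compound 2 thus holds the lowest number of the two measured, with compound 1 the only neighbour.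

Compound 3 `CCCCCCCCCCCCCCCCCCNC(=O)[C@@H](NS(=O)(=O)c1ccc(C)cc1)[C@@H](C)O` carries (4-methylphenyl)sulfonyl in place of benzoyl on an amine nitrogen. Going by the values given here, no measured step touches this position; the one step seen concerns the chain alone, so it gives no guide here. Compound 3 is therefore expected to show a 1.0-fold higher number from compound 2 to compound 3 (0.02 log units; within the scatter), a shift not beyond the scatter. Compound 3 is estimated at 40000 nM, with a range from 15000 nM to 110000 nM.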

Compound 3, half-maximal inhibitory concentration: 29800 nM
Compound 3: middle estimate off by 1.3-fold (0.13 log units), on the high side, and the stated range covers the measured number.
By their numbers in this assay, from the lowest: compounds 3 and 2 (each within the scatter of the next); then compound 1.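

In this assay the swap of benzoyl for (4-methylphenyl)sulfonyl on the amine nitrogen gives a 1.3-fold lower number from compound 2 to compound 3 (0.11 log units; within the scatter) with the chain of compound 2 held fixed. For the compounds shown here, this is the first reading at this position, and it separates neither group from the other, even though the entering group adds a sulfur and a hydrogen-bond acceptor by count. No supporting measurement bears on the reason for this result. Open, on these data alone, is how an acetyl group or a plain phenylsulfonyl group on this nitrogen would read. Also open, as far as these compounds go, is whether the sulfonyl swap reads the same on the shorter chain of compound 1.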